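Swapping a Hydroxyethyl Phenyl for a Fluorophenyl Group

The source may hold more compounds than are shown below. What is called first, only, known or untested is meant among the compounds shown, and "the series" means these compounds.

Compound 3 `CNC(=O)c1cc(C(=O)NC2CC2)cn(Cc2cccc([C@@H](C)O)c2)c1=O` is one of three measured compounds built on the same core. In a physicochemical assay for solubility (a lower number here means a less soluble compound, a higher number a more soluble compound), compound 3 gives a limit of the assay, >= 131 ug/mL, and not a number. Compound 2 `CNC(=O)c1cc(C(=O)NC2CC2)cn(CC2CCCOC2)c1=O` also returns a limit, >= 131 ug/mL. Compound 1 `CNC(=O)c1cc(C(=O)NC2CC2)cn(Cc2cccc(OC)c2)c1=O` gives a numerical value of 79 ug/mL. The two limits are set out in the limit of >= 131 ug/mL in this assay, at which 2 of the 3 values shown sit. The steps of an at least 1.6-fold higher number from compound 1 to compound 2 (0.21 log units; that floor lies within the scatter) and an at least 1.6-fold higher number from compound 1 to compound 3 (0.21 log units; that floor lies within the scatter) both point upward, while a step that the two limits leave unreadable from compound 2 to compound 3 cannot be read from the two limits.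

Compound 4 `CNC(=O)c1cc(C(=O)NC2CC2)cn(Cc2ccc(F)cc2)c1=O` has not yet been measured. It differs from compound 3 in one place: 4-fluorophenyl in place of 3-(1-hydroxyethyl)phenyl on a saturated chain carbon bound to an aromatic nitrogen. The step that bears on this change is an at least 1.6-fold higher number from compound 1 to compound 3 (0.21 log units; that floor lies within the scatter), in which the 1-hydroxyethyl group entered; compound 4 takes that group away again and carries a 4-fluorophenyl group instead. A downward step of an at least 3.2-fold lower number from compound 3 to compound 4 (0.51 log units; beyond the scatter) is therefore expected. Compound 4 is estimated at 40 ug/mL, within a range from 15 ug/mL to 110 ug/mL.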

Compound 4, solubility: >= 162 ug/mL
Compound 4: no number, only a limit (the forecaster's own chance of this, stated with the estimate: 10%); middle value at least 4.0-fold (0.60 log units) from the limit.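

In this assay compound 4 also returns a limit and not a number: the limit of >= 162 ug/mL in this assay, at which 1 of the 4 values shown sits. At this place on a saturated chain carbon bound to an aromatic nitrogen, a limit of the assay is therefore reached without the 1-hydroxyethyl group, by a 4-fluorophenyl group with 0 hydrogen-bond donors. The change from 3-methoxyphenyl to 4-fluorophenyl gives an at least 2.0-fold higher number from compound 1 to compound 4 (0.31 log units; beyond the scatter), the first step from compound 1 printed as beyond the scatter.

The steps among compound 2, compound 3 and compound 4 cannot be read, as each joins two limits, so these compounds remain unordered in this assay. Also open, as far as these compounds go, is whether a phenyl group carrying an amine or a carboxylic acid at this place would return a limit or a number.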